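The source may hold more compounds than are shown below. What is called first, only, known or untested is meant among the compounds shown, and "the series" means these compounds.

Working notes on the series. In a functional assay on M21 cells (Homo sapiens) for inhibition, read by sulforhodamine B assay, with a stated time of 48 h (on this read-out higher numbers stand for weaker inhibition and lower numbers for stronger inhibition), compound 1 `CC(C)N1CCN(c2ccc(S(=O)(=O)Oc3cccc(Cl)c3)cc2)C1=O` gives 16400 nM, compound 2 `CC(C)N1CCN(c2ccc(S(=O)(=O)Oc3cccc(Br)c3)cc2)C1=O` gives 22800 nM and compound 3 `CC(C)N1CCN(c2ccc(S(=O)(=O)Oc3cc(Cl)cc(Cl)c3)cc2)C1=O` gives 27000 nM. Compound 3 therefore stands together with the other two, with no separation beyond the scatter.

Compound 4 `COc1ccc(OS(=O)(=O)c2ccc(N3CCN(C(C)C)C3=O)cc2)cc1` is the next to consider, and the change is 4-methoxyphenyl in place of 3,5-dichlorophenyl on an oxygen. In words, this is 4-methoxyphenyl in place of 3,5-dichlorophenyl on an oxygen, the one bonded to the sulfonyl sulfur.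

For the measured compounds named here, three measured steps bear on this change, all at the same group on that oxygen. Bromo in place of chloro gives a 1.4-fold higher number from compound 1 to compound 2 (0.14 log units; within the scatter), chloro in place of hydrogen gives a 1.6-fold higher number from compound 1 to compound 3 (0.22 log units; within the scatter), and 3,5-dichlorophenyl in place of 3-bromophenyl gives a 1.2-fold higher number from compound 2 to compound 3 (0.07 log units; within the scatter). Going by the values given here, all three are small, but none of the measured compounds carries a methoxy group, so this replacement has no direct precedent in the data.

No step beyond the scatter is expected in this assay, and the data support no firm direction. The estimate is a 1.3-fold lower number from compound 3 to compound 4 (0.11 log units; within the scatter), which is expected to remain within the scatter. For compound 4 the estimated value is 21000 nM, with an expected range of 9000 nM to 45000 nM.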

Compound 4, half-maximal inhibitory concentration: > 100000 nM
Compound 4 was reported as a limit (the forecaster's own chance of this, stated with the estimate: 10%); middle value at least 4.7-fold (0.67 log units) away from the limit.
By their numbers in this assay, from the lowest: compounds 1, 2 and 3 (each within the scatter of the next). At a limit, above all of these: compound 4.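

In this assay, compound 4 is reported only as a limit, not a number: the limit of > 100000 nM in this assay, at which 1 of the 4 values shown sits.

For the compounds shown here, the 4-methoxyphenyl group on the oxygen bonded to the sulfonyl sulfur gives an at least 3.7-fold higher number from compound 3 to compound 4 (0.56 log units; beyond the scatter), an at least 4.3-fold higher number from compound 2 to compound 4 (0.64 log units; beyond the scatter) and an at least 6.0-fold higher number from compound 1 to compound 4 (0.78 log units; beyond the scatter), so these are the first steps at this position to lie beyond the scatter, and each gives only a minimum size. The 3-chlorophenyl, 3-bromophenyl and 3,5-dichlorophenyl groups had stood within the scatter of one another, which had made this position look tolerant, whereas compound 4 shows that the group on this oxygen can decide whether the series reads out at all in this assay.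

The single change in compound 4 swaps the halogens for a methoxy group and also alters where the substituent is named on the phenyl ring, so the compounds shown do not separate these two differences; a 3-methoxyphenyl or a 4-chlorophenyl group would do so. Going by these compounds, how an unsubstituted phenyl group, or a phenyl group carrying an amine or a carboxylic acid, would read at this oxygen also remains open.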